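Working notes: chloromethyl to iodomethyl from compound 2

A few compounds are considered here, and "the series" means these few. Any claim that something is new, unique, unknown or untested is made for them only; others in the source may bear on it.

Measured in a functional assay on HeLa cells (Homo sapiens) (a higher number here means that more compound is needed for the effect, a lower number that less compound is needed), so far:
- compound 1 `CCOC(=O)c1cc(CI)nn1C1O[C@@H](COC(C)=O)[C@H](OC(C)=O)[C@@H](OC(C)=O)[C@@H]1OC(C)=O` gives 2.5 ug/mL
- compound 2 `CC(=O)OC[C@@H]1OC(n2nc(CCl)cc2C(N)=O)[C@@H](OC(C)=O)[C@H](OC(C)=O)[C@H]1OC(C)=O` gives 18 ug/mL

Of the two values in this assay, compound 2 has the higher number at 18 ug/mL and compound 1 the lower at 2.5 ug/mL, a gap beyond the usual scatter.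

Compound 3 `CC(=O)OC[C@@H]1OC(n2nc(CI)cc2C(N)=O)[C@@H](OC(C)=O)[C@H](OC(C)=O)[C@H]1OC(C)=O` has not yet been measured. Its difference from compound 2 is iodo in place of chloro on a saturated chain carbon bound to an aromatic carbon and amounts to iodo in place of chloro on a saturated chain carbon bound to an aromatic carbon. Going by the values given here, no measured pair shows this change alone, so the data do not fix its size. Among the compounds with values here, the only pointer is that compound 1, which also carries iodomethyl, gives 2.5 ug/mL and thus the lower of the two numbers. That pointer is weak, so only a moderate move toward a lower number is expected, and the expected step is a 2.6-fold lower number from compound 2 to compound 3 (0.41 log units; beyond the scatter) in this reading. For compound 3 the estimated value is 7 ug/mL, with an expected range from 2.5 ug/mL to 20 ug/mL.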

Compound 3, concentration for half-maximal effect: 2 ug/mL
Beside the measured number, compound 3's estimate is 3.5-fold (0.54 log units) above it; measured number outside the range, below it.
By their numbers in this assay, from the lowest: compounds 3 and 1 (each within the scatter of the next); then compound 2.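

In this assay, going by these compounds alone, the step with only this change gives a 9.0-fold lower number from compound 2 to compound 3 (0.95 log units; beyond the scatter), the first direct reading of iodo in place of chloro on a saturated chain carbon bound to an aromatic carbon, and it shows that the identity of this halogen alone can shift the number beyond the scatter. With iodomethyl held constant, amino in place of ethoxy on a carbonyl carbon gives a 1.3-fold lower number from compound 1 to compound 3 (0.10 log units; within the scatter), so the amide and the ethyl ester are not separated in this setting. Nothing at hand gives a reason for either step.

As far as these compounds go, whether bromomethyl, hydroxymethyl or aminomethyl at this place would stay with the iodomethyl compounds or with the chloromethyl compound remains open, since the halogen step rests on a single pair. Also open, from the compounds shown here alone, is whether the carbonyl position would tolerate a carboxylic acid or a longer alkyl ester, and whether amino and ethoxy would also stay within the scatter of each other with chloromethyl in place of iodomethyl.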